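The source may report more compounds than this note shows. Statements on the series, on what has been measured and on what is new or still open speak of the compounds shown alone.

Measured compounds:
compound 1, `Cc1ccc(CNc2cc(Br)cc3[nH]ncc23)cc1`: 20%
compound 2, `O=C(O)c1cccc(CNc2ncnc3[nH]ncc23)c1`: 2%

In an assay for inhibition of Indoleamine 2,3-dioxygenase 1 (Homo sapiens), read by spectrophotometry, with a stated time of 180 min, tested at 10 uM (on this read-out higher numbers stand for a stronger effect at the one concentration tested and lower numbers for a weaker effect), compound 1 gives 20%, the higher of the two numbers. For the measured compounds named here, compound 2 gives 2%, a number lower by more than the usual scatter; since the two compounds differ in several places, their values show only that compound 1 inhibits more at the tested concentration. Compound 3, `Oc1ccc(CNc2cc(Br)cc3[nH]ncc23)cc1`, is not yet measured. It differs from compound 1 by hydroxy in place of methyl on an aromatic carbon. Going by the values given here, no measured pair shows what such a change does here. Compound 3 is expected to give 18%, within a range from 5% to 35%. This means a step of a number 2 percentage points lower from compound 1 to compound 3 (within the scatter) that is expected to stay within the scatter.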

Compound 3, a percentage reported as inhibition, at one concentration (the size of the read-out at that concentration, not a potency): 70%
Estimate against measurement, compound 3: 52 percentage points below; measured number above the stated range.
By their numbers in this assay, from the lowest: compound 2; then compound 1; then compound 3.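

In this assay, putting hydroxy in place of methyl brings a large gain, a number 50 percentage points higher from compound 1 to compound 3 (beyond the scatter), so a single-atom swap on this six-membered aromatic ring of carbon only, para to a large group, can strongly change inhibition. The shared core is unchanged in this pair, so the gain follows this one swap. Nothing available explains why the swap has this effect. On these data alone, what an amine or a methoxy group would do at the same place remains open. So does whether hydroxy would bring a similar gain at another place on this ring.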